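Same Hydroxymethyl Swap, Carried Onto a Second Core

The source may report more compounds than this note shows. Statements on the series, on what has been measured and on what is new or still open speak of the compounds shown alone.

Of the compounds shown here, three have been tested in a functional assay on Maver1 cells (Homo sapiens) for inhibition, read by luminescence and CellTiter-Glo, with a stated time of 72 h; on this read-out lower numbers stand for stronger inhibition and higher numbers for weaker inhibition. Compound 1, `C/C=C/C(=O)Nc1ccc(Cn2nc(-c3ccc(Oc4ccccc4)cc3)cc2C(=O)O)cc1`, gives > 60000 nM, which is a limit of the assay rather than a number. Compound 2, `C/C=C/C(=O)Nc1ccc(Cn2nc(-c3ccc(Oc4ccccc4)cc3)cc2CO)cc1`, differs from it by hydroxymethyl in place of carboxy on an aromatic carbon and gives 48400 nM. The measured step is an at least 1.2-fold lower number from compound 1 to compound 2 (0.09 log units; that floor lies within the scatter). Compound 3, `C/C=C/C(=O)N1CCCC(n2nc(-c3ccc(Oc4ccccc4)cc3)cc2C(=O)O)C1`, gives > 60000 nM, again a limit and not a number. The difference between the core of compound 1 and the core of compound 3 is not broken down here. The weight of these results is thin, as the limit of > 60000 nM in this assay, at which 2 of the 3 values shown sit, shows.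

Compound 4, `C/C=C/C(=O)N1CCCC(n2nc(-c3ccc(Oc4ccccc4)cc3)cc2CO)C1`, has not yet been measured. It differs from compound 3 by hydroxymethyl in place of carboxy on an aromatic carbon, the same change in the same place as the one from compound 1 to compound 2; among the compounds shown it occurs twice in all.

The step from compound 3 to compound 4 is expected to be an at least 1.2-fold lower number from compound 3 to compound 4 (0.07 log units; that floor lies within the scatter). Among the compounds with values here, that expectation rests on the step of an at least 1.2-fold lower number from compound 1 to compound 2 (0.09 log units; that floor lies within the scatter), the only case of this change with a measured value on one side, and its floor lies within the scatter. For compound 4 the estimate is 50000 nM, with a plausible range from 25000 nM to 100000 nM. Since compound 3 sits at a limit, compound 4 may well return only a limit as well.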

Compound 4, half-maximal inhibitory concentration: > 60000 nM
Compound 4: only a limit was reported (the forecaster's own chance of this, stated with the estimate: 55%); middle value at least 1.2-fold (0.07 log units) away from the limit.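

Compound 4 gives > 60000 nM in this assay, a limit and not a number. With compound 3 also at a limit, the step between compound 3 and compound 4 cannot be read. The compounds shown leave open whether hydroxymethyl in place of carboxy makes any difference on the core of compound 3, and they offer few actual numbers to judge it by: the limit of > 60000 nM in this assay, at which 3 of the 4 values shown sit.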